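The source may hold more compounds than are shown below. What is called first, only, known or untested is meant among the compounds shown, and "the series" means these compounds.

Measured so far:
compound 1 `Cn1c(=O)c2nc(-c3ccc(Cl)cc3)[nH]c2n(C)c1=O` 0.8 nM
compound 2 `CCCn1c(=O)c2nc(-c3ccc(S(=O)(=O)NCCCC(=O)OCC)cc3)[nH]c2n(CCC)c1=O` 0.24 nM
compound 3 `CCn1c(=O)c2nc(-c3ccc(S(=O)(=O)N4CCSCC4)cc3)[nH]c2n(CC)c1=O` 36.6 nM

In an assay for binding affinity to adenosine receptor A1 (Bos taurus) (on this read-out higher numbers stand for weaker inhibition and lower numbers for stronger inhibition), compound 1 gives 0.8 nM, the second highest of the three numbers; compound 2 sits beyond the scatter on the lower side, compound 3 well beyond it on the higher side. Compound 4 `CCc1ccc(-c2nc3c(=O)n(C)c(=O)n(C)c3[nH]2)cc1` has not yet been measured. It differs from compound 1 in one place: ethyl in place of chloro on an aromatic carbon. Among the measured compounds shown here, no step between two measured compounds covers this change, so the expectation rests on compound 1 alone. A step of about the size of the scatter is expected, if anything toward a higher number, a 1.9-fold higher number from compound 1 to compound 4 (0.27 log units; within the scatter). Compound 4 is therefore estimated at 1.5 nM, with a range from 0.4 nM to 6 nM.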

Compound 4, half-maximal inhibitory concentration: 0.8 nM
Beside the measured number, compound 4's estimate is 1.9-fold (0.27 log units) above it; the range from low to high includes it.
By their numbers in this assay, from the lowest: compound 2; then compounds 1 and 4 (each within the scatter of the next); then compound 3.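

In this assay, ethyl in place of chloro on an aromatic carbon, para to a large group, shows no change at the digits printed from compound 1 to compound 4 (within the scatter). Among the compounds shown here, this is the first step that changes one place only, and on the core of compound 1 it does not separate the two groups at this position. Nothing at hand accounts for this result.

Open, as far as these compounds go, is whether a longer chain such as butyl, an amine or a carboxylic acid at this position would fit the same picture. Also open, from the compounds shown here alone, is whether the ethyl and chloro exchange reads the same on the core of compound 2.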